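Changing the amide group on compound 3

The source may hold more compounds than are shown below. What is called first, only, known or untested is meant among the compounds shown, and "the series" means these compounds.

In a functional assay on MDA-MB-231 cells (Homo sapiens) for antiproliferative activity, read by MTT assay, with a stated time of 24 h (on this read-out higher numbers stand for weaker inhibition and lower numbers for stronger inhibition), compound 1 `CCCCc1oc2ccccc2c1C(=O)c1ccc(OCC(N)=O)cc1` gives only a limit, > 50000 nM. Compound 2 `CCCCc1oc2ccccc2c1C(=O)c1ccc(OCC(=O)Nc2ccccc2)cc1` also gives only a limit, > 50000 nM. Compound 3 `CCCCc1oc2ccccc2c1C(=O)c1ccc(OCCCC(=O)N2CCCC2)cc1` alone has a real number, 48700 nM. The series therefore sits close to the limit of > 50000 nM in this assay, at which 2 of the 3 values shown sit.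

Compound 4 `CCCCc1oc2ccccc2c1C(=O)c1ccc(OCCCC(=O)N[C@H](C)c2ccccc2)cc1` carries (1-phenylethyl)amino in place of pyrrolidin-1-yl on a carbonyl carbon.

Going by the values given here, two measured steps bear on this change: an at least 1.0-fold lower number from compound 1 to compound 3 (0.01 log units; that floor lies within the scatter), and an at least 1.0-fold lower number from compound 2 to compound 3 (0.01 log units; that floor lies within the scatter). A third, a step that the two limits leave unreadable from compound 1 to compound 2, gives no size at all. With so little movement, no shift beyond the scatter is expected in this assay. The expected change is a 1.2-fold lower number from compound 3 to compound 4 (0.09 log units; within the scatter). Compound 4 is estimated at 40000 nM, within a range of 12000 nM to 70000 nM.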

Compound 4, half-maximal inhibitory concentration: > 50000 nM
Compound 4: only a limit was reported; the forecaster's own chance of this, stated with the estimate: 45%; middle value at least 1.2-fold (0.09 log units) from the limit.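

In this assay, the change to (1-phenylethyl)amino on this carbonyl carbon gives an at least 1.0-fold higher number from compound 3 to compound 4 (0.01 log units; that floor lies within the scatter). Compound 4 gives only a limit, so a larger amide group carrying a six-membered aromatic ring and an amide hydrogen brings no sign of stronger inhibition here. Compound 4 also adds to the values that give no size for any effect: the limit of > 50000 nM in this assay, at which 3 of the 4 values shown sit.

Going by these compounds, what a carboxylic acid or a morpholin-4-yl group would give on this carbonyl carbon remains open. So does the effect of the opposite stereocentre in the 1-phenylethyl group.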